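The source may report more compounds than this note shows. Statements on the series, on what has been measured and on what is new or still open speak of the compounds shown alone.

In a functional assay on PC-3 cells (Homo sapiens) for antiproliferative activity, read by MTT assay, with a stated time of 24 h (a lower number here means a stronger inhibitor, a higher number a weaker inhibitor), compound 1 `CCn1c(C(=O)NCCC(=O)OC)ccc1C(CC)(CC)c1ccc(OCS(=O)(=O)c2ccccc2)c(C)c1` gives 40400 nM and compound 2 `CCn1c(C(=O)N[C@@H](CC(=O)OC)C(=O)OC)ccc1C(CC)(CC)c1ccc(OCS(=O)(=O)c2ccccc2)c(C)c1` gives 6490 nM while compound 3 `CCn1c(C(=O)N[C@@H](C)CO)ccc1C(CC)(CC)c1ccc(OCS(=O)(=O)c2ccccc2)c(C)c1` gives 9520 nM on the same core. Compound 2 stands with compound 3 at the low end of these numbers, clear of compound 1. Compound 4 `CCn1c(C(=O)NC(C)(C)CO)ccc1C(CC)(CC)c1ccc(OCS(=O)(=O)c2ccccc2)c(C)c1` carries 1-(hydroxymethyl)-1-methylethyl in place of 1,2-bis(methoxycarbonyl)ethyl on an amide-type nitrogen. For the measured compounds named here, the nearest precedent, a 1.5-fold higher number from compound 2 to compound 3 (0.17 log units; within the scatter) on moving to 1-(hydroxymethyl)ethyl, stays within the scatter, whereas a 6.2-fold lower number from compound 1 to compound 2 (0.79 log units; beyond the scatter) and a 4.2-fold lower number from compound 1 to compound 3 (0.63 log units; beyond the scatter) both start from the 2-(methoxycarbonyl)ethyl amide and bear less directly. Hence no step beyond the scatter is expected in this assay and the estimated step of a 1.4-fold higher number from compound 2 to compound 4 (0.14 log units; within the scatter) stays small. Compound 4 is expected at 9000 nM within an estimated range of 3500 nM to 24000 nM for now.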

Compound 4, half-maximal inhibitory concentration: 9850 nM
Compound 4: the middle estimate sits 1.1-fold (0.04 log units) below what was measured, and the stated range covers the measured number.
By their numbers in this assay, from the lowest: compounds 2, 3 and 4 (each within the scatter of the next); then compound 1.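

In this assay, 1-(hydroxymethyl)-1-methylethyl and 1-(hydroxymethyl)ethyl on the amide-type nitrogen cannot be told apart, with a 1.0-fold higher number from compound 3 to compound 4 (0.01 log units; within the scatter), so this position accepts a group without a defined stereocentre. With a 1.5-fold higher number from compound 2 to compound 4 (0.18 log units; within the scatter) and a 4.1-fold lower number from compound 1 to compound 4 (0.61 log units; beyond the scatter), a group with no methoxycarbonyl stays level with 1,2-bis(methoxycarbonyl)ethyl and clear of 2-(methoxycarbonyl)ethyl, so methoxycarbonyl is not needed for the lower numbers. No measurement bears on why these steps take this size. Open, as far as these compounds go, is whether a carboxylic acid, an amine or a longer hydroxyalkyl chain on this nitrogen would move the number beyond the scatter of compound 2, compound 3 and compound 4.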